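Isopropyl in Place of Hydrogen: What to Expect

A few compounds are considered here, and "the series" means these few. Any claim that something is new, unique, unknown or untested is made for them only; others in the source may bear on it.

Of the compounds shown here, two sharing one core have been tested in a functional assay on the whole organism for inhibition, with Rattus norvegicus as the target, at a dose of 0.3 mg/kg by the oral route; a lower number here means a weaker effect, a higher number a stronger effect of the compound at the dose given. Compound 1 `CCOc1cc(C(=O)Nc2nn[nH]n2)nc(-c2ccc(N)cc2)c1` gives 19% in this assay. Compound 2 `Nc1ccc(-c2cccc(C(=O)Nc3nn[nH]n3)n2)cc1` gives 11% in this assay, a number that sits no further from compound 1 than repeated measurements of this kind usually do. Among the measured compounds shown here, the single step between measured compounds is a number 8 percentage points lower from compound 1 to compound 2 (within the scatter), the change being hydrogen in place of ethoxy on an aromatic carbon.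

Compound 3 `CC(C)c1cc(C(=O)Nc2nn[nH]n2)nc(-c2ccc(N)cc2)c1` has not yet been measured in this assay. For the measured compounds named here, it differs from compound 2 in one place: isopropyl in place of hydrogen on an aromatic carbon This is the same aromatic carbon that carried ethoxy in compound 1 and hydrogen in compound 2, so the one measured step that bears on it is a number 8 percentage points lower from compound 1 to compound 2 (within the scatter), and that step lay within the scatter. With ethoxy and hydrogen at that carbon giving numbers within the scatter of each other, a third group there offers no ground for expecting a step beyond it. The step is expected to be a number 4 percentage points higher from compound 2 to compound 3 (within the scatter). Compound 3 is therefore estimated at 15% in this assay, with a range from 4% to 30%.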

Compound 3, a percentage reported as inhibition, in the whole organism at one dose (the size of the read-out at that dose, not a potency): 22%
Compound 3: middle estimate off by 7 percentage points, on the low side, within the range that was stated.
By their numbers in this assay, from the lowest: compounds 2, 1 and 3 (each within the scatter of the next, the first and the last beyond it).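

At this aromatic carbon, opposite the ring nitrogen, a substituent now gives a step that can be read: in this assay, isopropyl in place of hydrogen gives a number 11 percentage points higher from compound 2 to compound 3 (beyond the scatter), whereas the earlier change from ethoxy to hydrogen stayed within the scatter. Isopropyl in place of ethoxy gives a number 3 percentage points higher from compound 1 to compound 3 (within the scatter), so these two groups cannot be told apart here, and only the isopropyl and hydrogen pair is separated, by a modest margin at one oral dose. Nothing available explains why isopropyl separates from hydrogen at this carbon, and the size of the read-out at a single dose says nothing about potency.

The compounds shown leave open whether a longer chain such as n-butyl, or an amine or a carboxylic acid, at this same carbon would fall with isopropyl and ethoxy or with hydrogen. They also leave open whether the gap between isopropyl and hydrogen would persist at another dose, or on a core carrying a different group in place of the 4-aminophenyl group.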